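The source may report more compounds than this note shows. Statements on the series, on what has been measured and on what is new or still open speak of the compounds shown alone.

Measured compounds:
Compound 1 `COC(C)CO[C@H](CC=C(C)C)C1=CC(=O)c2c(O)ccc(O)c2C1=O`: 16600 nM
Compound 2 `CC(C)=CC[C@@H](OC[C@@H](C)O)C1=CC(=O)c2c(O)ccc(O)c2C1=O`: 14300 nM
Compound 3 `CCCC(CC(=O)O[C@H](CC=C(C)C)C1=CC(=O)c2c(O)ccc(O)c2C1=O)OC(C)=O`: 55700 nM

In a functional assay on DU-145 cells (Homo sapiens) for cytotoxicity, read by MTT assay (a higher number here means a weaker inhibitor, a lower number a stronger inhibitor), compound 3 gives the highest of the three numbers: compound 1 sits nearer to it, compound 2 further away, and both gaps lie beyond the scatter. Compounds 1 and 2 carry ether side chains on the shared core, whereas compound 3 carries an ester, and compound 3 is the weaker inhibitor of the set in this assay.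

Compound 4 `CCC(C)(O)CC(=O)O[C@H](CC=C(C)C)C1=CC(=O)c2c(O)ccc(O)c2C1=O` keeps the ester of compound 3 and changes the acid side: 1-hydroxy-1-methylpropyl in place of 1-acetoxybutyl on a saturated chain carbon bound to a carbonyl carbon. For the measured compounds named here, only one measured step bears on this at all. It swaps a methoxy-bearing carbon for a hydroxy-bearing one, a 1.2-fold lower number from compound 1 to compound 2 (0.06 log units; within the scatter), and shows that gaining a hydroxyl there left this assay essentially unchanged. Going by the values given here, no measured pair speaks to the loss of the acetoxy group or the shortening of the chain on a saturated chain carbon bound to a carbonyl carbon. The step from compound 3 to compound 4 is therefore expected to stay within the scatter, with at most a modest drift toward a lower number, a 1.4-fold lower number from compound 3 to compound 4 (0.14 log units; within the scatter). Compound 4 is estimated to give 40000 nM in this assay, within a range from 15000 nM to 110000 nM.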

Compound 4, half-maximal inhibitory concentration: 16000 nM
Estimate against measurement, compound 4: 2.5-fold (0.40 log units) above, and the stated range covers the measured number.
By their numbers in this assay, from the lowest: compounds 2, 4 and 1 (each within the scatter of the next); then compound 3.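

In this assay, putting 1-hydroxy-1-methylpropyl in place of 1-acetoxybutyl on a saturated chain carbon bound to a carbonyl carbon gives a 3.5-fold lower number from compound 3 to compound 4 (0.54 log units; beyond the scatter), the first step shown at this place and one that lies beyond the scatter. It also shows that the ester link alone does not set the higher number: the comparisons with the ether side chains give a 1.1-fold higher number from compound 2 to compound 4 (0.05 log units; within the scatter) and a 1.0-fold lower number from compound 1 to compound 4 (0.02 log units; within the scatter), so among these compounds the higher number stays with compound 3 and its 1-acetoxybutyl group. No measurement shown here accounts for this step.

The change removes the acetoxy group, adds a hydroxyl and alters the chain all at once, so the compounds shown do not separate these parts, and a 1-hydroxybutyl group at the same place would be needed to begin doing so. Going by these compounds, how this place would respond to an amine, a carboxylic acid or a longer chain also remains open.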